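This account rests on a few compounds, and the source may have more. Where it says the series, first, only, none or still open, it means among the compounds named here.

Compound 2 `CCC1(CCCCN2CCN(c3ccc(OC)cc3)CC2)C(=O)Nc2ccccc21` reaches only a limit in a functional assay on the whole organism (strain Wistar) with Rattus norvegicus as the target, with a stated time of 5 min (a lower number here means that less compound is needed, a higher number that more compound is needed for the effect), namely > 20 mg/kg. Compound 1 `CCC1(CCCCN2CCN(c3cccc(Cl)c3)CC2)C(=O)Nc2cc(F)ccc21` also stops at a limit, > 20 mg/kg. Compound 3 `CCC1(CCCCN2CCN(c3cccc(Cl)c3)CC2)C(=O)Nc2ccccc21` differs from compound 2 by 3-chlorophenyl in place of 4-methoxyphenyl on an amine nitrogen in a ring. No measured step joins any two of these compounds, and the values shown both rest at the limit of > 20 mg/kg in this assay, at which 2 of the 2 values shown sit, so no direction can be read from them. The expected step is a step that the limit leaves unreadable from compound 2 to compound 3, nothing beyond the usual scatter. Compound 3 is therefore estimated at 25 mg/kg, within a range from 12 mg/kg to 50 mg/kg, and a further limit rather than a number is the more likely outcome.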

Compound 3, minimum effective dose: > 20 mg/kg
Compound 3 gave a limit, no number; the forecaster's own chance of this, stated with the estimate: 80%; the middle value is on the limit's open side.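

No step can be read among compound 1, compound 2 and compound 3, since all three rest at the same limit of the assay: the limit of > 20 mg/kg in this assay, at which 3 of the 3 values shown sit.

What the compounds shown leave open is whether 3-chlorophenyl or 4-methoxyphenyl, or fluoro or hydrogen, changes the dose needed in this assay.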